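The compounds below may be only part of what the source reports. "The series", "measured", "known", "first", "only" and "open" are said of these compounds alone.

Among the compounds with values here, the two compounds measured so far share one core. Compound 1 `CNc1c(C)nc2c(OCc3ccccc3)cccn12` carries a methylamino group, and in a functional assay on the whole organism with Rattus norvegicus as the target (on this read-out lower numbers stand for an effect already at smaller amounts and higher numbers for an effect only at larger amounts of compound), compound 1 gives 9.8 mg/kg. Compound 2 `Cc1nc2c(OCc3ccccc3)cccn2c1NC(C)C` carries an isopropylamino group in the same place, and in this assay compound 2 gives 16 mg/kg. Compound 2 therefore stands alongside compound 1, the two numbers being within the scatter of each other, as the step of a 1.6-fold higher number from compound 1 to compound 2 (0.21 log units; within the scatter) shows.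

Compound 3 `COc1c(C)nc2c(OCc3ccccc3)cccn12` has not yet been measured. The change from compound 2 to compound 3 is methoxy in place of isopropylamino on an aromatic carbon. Within the data shown here, only one measured step exists, and it swaps one alkyl chain for another while keeping the nitrogen in place, so it bears on the new change only loosely and shows no movement beyond the scatter. Nothing in the measured compounds tells what happens when the nitrogen itself is exchanged. Relative to compound 2, the step expected for compound 3 is a 1.6-fold higher number from compound 2 to compound 3 (0.19 log units; within the scatter), with wide uncertainty. The estimate for compound 3 in this assay is 25 mg/kg, expected to fall between 8 mg/kg and 80 mg/kg.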

Compound 3, dose for half-maximal effect: 3.6 mg/kg
Beside the measured number, compound 3's estimate is 6.9-fold (0.84 log units) above it, outside the stated range (below it).
By their numbers in this assay, from the lowest: compound 3; then compounds 1 and 2 (each within the scatter of the next).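

Exchanging the amine for an ether at this aromatic carbon on the five-membered ring shifts the result in this assay beyond the scatter: methoxy in place of isopropylamino gives a 4.4-fold lower number from compound 2 to compound 3 (0.65 log units; beyond the scatter), and methoxy in place of methylamino gives a 2.7-fold lower number from compound 1 to compound 3 (0.43 log units; beyond the scatter). The earlier step altered only the alkyl chain on the nitrogen and stayed within the scatter, so this position responds to a change that the first two compounds could not reveal, and both amines point the same way when methoxy enters. Nothing available gives a reason for this shift.

The compounds shown leave open whether the oxygen itself matters or the loss of the hydrogen-bond donor carried by the amine, a question that a dimethylamino group, with nitrogen in the same place but no hydrogen on it, could help to separate. They also leave open whether the lower number would hold with a longer chain on the oxygen, such as ethoxy or isopropoxy.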